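The source may report more compounds than this note shows. Statements on the series, on what has been measured and on what is new or still open speak of the compounds shown alone.

Compound 1, `CCOC(=O)CN(C)C(=O)c1ccc(C(CC)(CC)c2ccc(OCC(O)C(C)(C)C)c(C)c2)n1CC`, with 10100 nM in an ADME assay on L02 cells (Homo sapiens) for cytotoxicity, read by MTT assay, with a stated time of 48 h; on this read-out higher numbers stand for weaker inhibition and lower numbers for stronger inhibition.
Compound 2, `CCn1c(C(=O)N(C)CCC#N)ccc1C(CC)(CC)c1ccc(OCC(O)C(C)(C)C)c(C)c1`, with 14900 nM in this assay.

Among the measured compounds shown here, of these two numbers, compound 2 carries the larger one, yet the only step joining them, a 1.5-fold higher number from compound 1 to compound 2 (0.17 log units; within the scatter), lies within the scatter, so the two compounds cannot be separated on this read-out. Compound 3, `CCn1c(C(=O)N(C)CC(=O)O)ccc1C(CC)(CC)c1ccc(OCC(O)C(C)(C)C)c(C)c1`, differs from compound 2 in one place: carboxy in place of cyanomethyl on a saturated chain carbon bound to an amide-type nitrogen. For the measured compounds named here, the single measured step also swaps one group for another on a saturated chain carbon bound to an amide-type nitrogen, and it shifted the number only within the scatter. Going by the values given here, no measured step brings in a carboxy group, so the expectation rests on that one small step alone. Compound 3 is therefore expected to move from compound 2 by a 1.2-fold higher number from compound 2 to compound 3 (0.08 log units; within the scatter), not beyond the scatter. For compound 3 the estimate in this assay is 18000 nM, with a range from 8000 nM to 40000 nM.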

Compound 3, half-maximal inhibitory concentration: 32600 nM
Compound 3: middle estimate off by 1.8-fold (0.26 log units), on the low side; the measured number falls inside the stated range.
By their numbers in this assay, from the lowest: compounds 1 and 2 (each within the scatter of the next); then compound 3.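

On a saturated chain carbon bound to an amide-type nitrogen, a swap now moves the number in this assay beyond the scatter: carboxy in place of cyanomethyl gives a 2.2-fold higher number from compound 2 to compound 3 (0.34 log units; beyond the scatter) and so goes further than the earlier swap at this place. Hydrogen in place of ethyl on an oxygen next to a carbonyl group gives a 3.2-fold higher number from compound 1 to compound 3 (0.51 log units; beyond the scatter) and, though also modest, shows that the carboxy compound stands apart from both neighbours, with weaker inhibition on this read-out. No measurement available here explains this rise.

On these data alone, it remains open whether a primary amide or an amine at this place would give a similar number. As far as these compounds go, whether a longer chain carrying the carboxy group would raise or lower the number also remains unknown.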